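Fluoroalkyl swap on the shared core, compound 3 to compound 4

The compounds below may be only part of what the source reports. "The series", "measured", "known", "first", "only" and "open" are said of these compounds alone.

Measured so far in an in vitro ADME assay on microsomes from liver (Simiiformes); on this read-out lower numbers stand for a shorter-lived compound and higher numbers for a longer-lived compound:
- compound 1, `Cc1cc(-c2noc(C(F)(F)F)n2)cc(C)c1OCCCc1cc(CO)no1`: > 2.5 h
- compound 2, `Cc1cc(-c2noc(C(F)(F)F)n2)cc(C)c1OCCCc1cc(CS(C)(=O)=O)no1`: > 2.5 h
- compound 3, `Cc1cc(CCCOc2c(C)cc(-c3noc(CC(F)(F)F)n3)cc2C)on1`: 0.533 h

The readings of compound 1 and of compound 2 in this assay are limits of the assay, not numbers; the limit of > 2.5 h in this assay, at which 2 of the 3 values shown sit, applies to both. Among the compounds with values here, compound 3 is therefore the only compound of the three with a numerical half-life in this assay, and it sits below the limit at which the other two values rest. Within the data shown here, the single measured step, a step that the two limits leave unreadable from compound 1 to compound 2, is unreadable on both sides and gives no guidance on the size a one-place change can produce here.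

Compound 4, `Cc1cc(CCCOc2c(C)cc(-c3noc(C(C)(F)F)n3)cc2C)on1`, differs from compound 3 in one place: 1,1-difluoroethyl in place of 2,2,2-trifluoroethyl on an aromatic carbon. Among the measured compounds shown here, no measured step involves this position or either of the two groups, so nothing among the measured compounds bears on the change directly. With no evidence for movement in either direction, a step within the usual scatter is expected, a 1.1-fold higher number from compound 3 to compound 4 (0.05 log units; within the scatter). The half-life of compound 4 in this assay is estimated at 0.6 h, with a likely range from 0.3 h to 1.5 h.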

Compound 4, half-life: 1.1 h
For compound 4 the middle estimate is 1.8-fold (0.26 log units) below the measured one; the range from low to high includes it.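

In this assay, the group on the aromatic carbon next to the ring nitrogen and next to the ring oxygen proves able to move the half-life: 1,1-difluoroethyl in place of 2,2,2-trifluoroethyl gives a 2.1-fold higher number from compound 3 to compound 4 (0.31 log units; beyond the scatter). Within the data shown here, the only earlier step cannot be read, so this is the first one-place change with a readable size, and it is a modest one. Neither group carries a ring, a hydrogen-bond donor, a hydrogen-bond acceptor or a net charge, so a change at this position registers with all of these counts unchanged, and both compounds give numbers rather than the limit of the read-out: the limit of > 2.5 h in this assay, at which 2 of the 4 values shown sit.

A single step leaves open whether the shift follows the number of fluorine atoms or the chain carbon that bears them, and the compounds shown give no cause for it. As far as these compounds go, how a plain ethyl or a cyclopropyl group at this position would read in this assay also remains open, as does whether this step would carry over to the core of compound 1, which bears a hydroxymethyl group.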